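This account rests on a few compounds, and the source may have more. Where it says the series, first, only, none or still open, it means among the compounds named here.

Compound 1 `COc1cc(NC(=O)Nc2cc(Nc3cccc(C(C)(C)C)c3)ncn2)cc(OC)c1`, compound 3 `COc1cc(NC(=O)Nc2cc(Nc3cc(Br)ccc3OC)ncn2)cc(OC)c1` and compound 2 `COc1ccc(Br)cc1Nc1cc(NC(=O)Nc2c(Cl)cccc2Cl)ncn1` share one core and have all been tested in a functional assay on NCI-H1581 cells (Homo sapiens) for inhibition, read by MTT assay, with a stated time of 48 h, tested at 10 uM; a higher number here means more inhibition at the concentration tested (going by the name of the read-out), a lower number less inhibition. Compound 1 gives 35.1%, compound 3 gives 23.1% and compound 2 gives 53.3%. Compound 1 and compound 3 differ at one position only, (3-(tert-butyl)phenyl in place of 5-bromo-2-methoxyphenyl on a nitrogen on an aromatic ring), and that exchange gave a number 12 percentage points lower from compound 1 to compound 3 (beyond the scatter). Compound 2 differs from compound 3 by 2,6-dichlorophenyl in place of 3,5-dimethoxyphenyl on an amide-type nitrogen, and this exchange gave a number 30.2 percentage points higher from compound 3 to compound 2 (beyond the scatter). Compound 4 `CC(C)(C)c1cccc(Nc2cc(NC(=O)Nc3c(Cl)cccc3Cl)ncn2)c1`, not yet measured, carries exactly the same change on the core of compound 1: 2,6-dichlorophenyl in place of 3,5-dimethoxyphenyl on an amide-type nitrogen. Because the earlier exchange gave a number 30.2 percentage points higher from compound 3 to compound 2 (beyond the scatter), a step of similar size is expected here, a number 27.9 percentage points higher from compound 1 to compound 4 (beyond the scatter), although this rests on a single measured pair. For compound 4 the estimate in this assay is 63%, expected to fall between 42% and 84%.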

Compound 4, a percentage reported as inhibition, at one concentration (the size of the read-out at that concentration, not a potency): 64.3%
Compound 4: middle estimate off by 1.3 percentage points, on the low side; low and high end bracket the measured number.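

Swapping 3,5-dimethoxyphenyl for 2,6-dichlorophenyl on an amide-type nitrogen gave, in this assay, a number 29.2 percentage points higher from compound 1 to compound 4 (beyond the scatter). The same change therefore had much the same size on both cores: the same change on two cores in this assay, a number 30.2 percentage points higher (beyond the scatter) from compound 3 to compound 2 and a number 29.2 percentage points higher (beyond the scatter) from compound 1 to compound 4, 1 percentage points apart, within the scatter of two such steps. Among these compounds, this is only two pairs, each read at one concentration, which shows that the step carried over between these two cores, but not that it would carry to other cores, nor why the number rises.

The compounds shown leave open how much of the step depends on the chlorines, as a phenyl ring with a single chlorine or with two methyl groups would test. Going by these compounds, it also remains open whether the step survives with an amine or a carboxylic acid on the shared core.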